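Methoxypyridyl for methylpyridyl on a shared core

This account rests on a few compounds, and the source may have more. Where it says the series, first, only, none or still open, it means among the compounds named here.

Compound 1 `N#Cc1ccccc1-c1cnc(C(=O)CCCCCCc2ccccc2)o1`: 130 nM
Compound 2 `Cc1cccc(-c2cnc(C(=O)CCCCCCc3ccccc3)o2)n1`: 3.3 nM

Within the data shown here, in an assay (Rattus norvegicus) for inhibition of Fatty-acid amide hydrolase 1 (Homo sapiens) (a lower number here means a stronger inhibitor, a higher number a weaker inhibitor), compound 2 holds the lowest of the two numbers measured so far, and the single measured step, a 39-fold lower number from compound 1 to compound 2 (1.60 log units; beyond the scatter), came from exchanging the whole aryl group on the shared core. Compound 3 `COc1ccnc(-c2cnc(C(=O)CCCCCCc3ccccc3)o2)c1` differs from compound 2 by 4-methoxypyridin-2-yl in place of 6-methylpyridin-2-yl on an aromatic carbon. Among the measured compounds shown here, no measured step tests this particular exchange; the one step only shows that the group at this place can move the number strongly. A modest rise is expected, a 2.1-fold higher number from compound 2 to compound 3 (0.33 log units; beyond the scatter). Compound 3 is estimated at 7 nM, within 2 nM to 30 nM.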

Compound 3, inhibition constant: 0.8 nM
Estimate against measurement, compound 3: 8.8-fold (0.94 log units) above; the whole stated range lies above it.
By their numbers in this assay, from the lowest: compound 3; then compound 2; then compound 1.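

In this assay, the step of a 4.1-fold lower number from compound 2 to compound 3 (0.62 log units; beyond the scatter) shows that this place still responds when a six-membered aromatic ring with 1 hetero atom stays in place and only its substituent changes. Measured against the 2-cyanophenyl group, the exchange spans a 160-fold lower number from compound 1 to compound 3 (2.21 log units; beyond the scatter). No measured property bears on this result. The compounds shown leave open whether the methoxy group or its location on the ring carries the step. They also leave open how an ethoxy group, a hydroxyl or an amine would fare there.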